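Nucleoside Transporter Inhibitors: Swapping the Benzyl Substituent

The compounds below may be only part of what the source reports. "The series", "measured", "known", "first", "only" and "open" are said of these compounds alone.

Compound 1 `OC[C@H]1O[C@@H](n2cnc3c(SCc4ccccc4Cl)ncnc32)[C@H](O)[C@@H]1O`: 117 nM
Compound 2 `OC[C@H]1O[C@@H](n2cnc3c(SCc4ccc(Br)cc4)ncnc32)[C@H](O)[C@@H]1O`: 11.5 nM
Compound 3 `N#Cc1cccc(CSc2ncnc3c2ncn3[C@@H]2O[C@H](CO)[C@@H](O)[C@H]2O)c1`: 36.3 nM

Three compounds share a core and differ only in the aryl group on the saturated chain carbon bound to a sulfur. In an assay on isolated protein for inhibition of Equilibrative nucleoside transporter 1 (Homo sapiens) (a higher number here means a weaker inhibitor, a lower number a stronger inhibitor), compound 1 gives 117 nM, compound 2 gives 11.5 nM and compound 3 gives 36.3 nM. Compound 3 thus stands second highest of the three: a 3.2-fold higher number from compound 2 to compound 3 (0.50 log units; beyond the scatter), while a 3.2-fold lower number from compound 1 to compound 3 (0.51 log units; beyond the scatter). The largest step shown is a 10-fold lower number from compound 1 to compound 2 (1.01 log units; beyond the scatter).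

Compound 4 `Cc1ccc(CSc2ncnc3c2ncn3[C@@H]2O[C@H](CO)[C@@H](O)[C@H]2O)cc1` carries the change (4-methylphenyl in place of 3-cyanophenyl on a saturated chain carbon bound to a sulfur). Going by the values given here, no measured step joins a 3-cyanophenyl to a 4-methylphenyl directly. The step that bears most on it is a 3.2-fold higher number from compound 2 to compound 3 (0.50 log units; beyond the scatter), since compound 2 also carries its substituent at the 4-position of the phenyl ring. Compound 4 is therefore expected to land between compound 2 and compound 3. Compound 4 is expected to show a 2.0-fold lower number from compound 3 to compound 4 (0.30 log units; within the scatter). Compound 4 is estimated at 18 nM, in the range 7 nM to 45 nM.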

Compound 4, inhibition constant: 15.1 nM
The estimate for compound 4 lay 1.2-fold (0.08 log units) above the measured number; measured number inside the range.
By their numbers in this assay, from the lowest: compounds 2 and 4 (each within the scatter of the next); then compound 3; then compound 1.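

In this assay, methyl in place of bromo on an aromatic carbon gives a 1.3-fold higher number from compound 2 to compound 4 (0.12 log units; within the scatter) and so leaves the number unchanged within the scatter, showing that the 4-methylphenyl and 4-bromophenyl groups cannot be told apart here. Both now stand apart from the other two groups, since the change from 3-cyanophenyl gives a 2.4-fold lower number from compound 3 to compound 4 (0.38 log units; beyond the scatter) and the change from 2-chlorophenyl gives a 7.7-fold lower number from compound 1 to compound 4 (0.89 log units; beyond the scatter) at this saturated chain carbon bound to a sulfur. Nothing available explains this order of the groups.

The compounds shown leave open whether the differences follow the place on the phenyl ring or the group itself, which a 3-methylphenyl or 4-cyanophenyl group would help to separate. They also leave open how far the trend extends to a 4-aminophenyl or 4-carboxyphenyl group, or to a longer chain before the ring.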